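The source may report more compounds than this note shows. Statements on the series, on what has been measured and on what is new or still open speak of the compounds shown alone.

Measured so far:
compound 1 `COc1cc(-c2cc(/C=C/C(=O)c3ccc(N)cc3)[nH]n2)cc(OC)c1OC` — 95%
compound 2 `COc1cc(-c2cc(/C=C/C(=O)c3ccc(Cl)c(Cl)c3)[nH]n2)cc(OC)c1OC` — 98%
compound 3 `COc1ccc(C(=O)/C=C/c2cc(-c3cc(OC)c(OC)c(OC)c3)n[nH]2)cc1OC` — 98%

In a functional assay on Hs-578T cells (Homo sapiens) for cytotoxicity, read by sulforhodamine B assay, with a stated time of 48 h, tested at 0.01 uM (a higher number here means a weaker effect of the compound at the concentration tested, a lower number a stronger effect), compound 3 is level with compound 2 at the digits given, and the two share the highest number of the three; compound 1 lies only slightly lower, a number 3 percentage points higher from compound 1 to compound 3 (within the scatter), so all three sit within the scatter of one another. Compound 4 `COc1ccc(C(=O)/C=C/c2cc(-c3cc(OC)c(OC)c(OC)c3)n[nH]2)cc1` differs from compound 3 by hydrogen in place of methoxy on an aromatic carbon. Among the compounds with values here, the steps that bear on this change all alter the aryl group on the carbonyl carbon: a number 3 percentage points higher from compound 1 to compound 2 (within the scatter), a number 3 percentage points higher from compound 1 to compound 3 (within the scatter) and no change at the digits printed from compound 2 to compound 3 (within the scatter), none beyond the scatter. The step to compound 4 is therefore expected to be small, a number 1 percentage points lower from compound 3 to compound 4 (within the scatter), with no direction beyond the scatter. Compound 4 is estimated at 97%, between 89% and 103%.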

Compound 4, a percentage reported as activity, at one concentration (the size of the read-out at that concentration, not a potency): 99%
Beside the measured number, compound 4's estimate is 2 percentage points below it; measured number inside the range.
By their numbers in this assay, from the lowest: compounds 1, 2, 3 and 4 (each within the scatter of the next).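

In this assay, hydrogen in place of methoxy, ortho to a methoxy group, gives a number 1 percentage points higher from compound 3 to compound 4 (within the scatter) and so shows that this methoxy can go without a step beyond the scatter. The 4-methoxyphenyl group also stays within the scatter of the other aryl groups on the carbonyl carbon, with a number 1 percentage points higher from compound 2 to compound 4 (within the scatter) for 3,4-dichlorophenyl and a number 4 percentage points higher from compound 1 to compound 4 (within the scatter) for the amino group in place of methoxy. No evidence is available to explain these results. Going by these compounds, whether a carboxylic acid or a longer alkoxy chain at this position would give a step beyond the scatter remains open, as does how these compounds compare at other concentrations.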